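A Shorter Chain on a Core That Shows No Inhibition

A few compounds are considered here, and "the series" means these few. Any claim that something is new, unique, unknown or untested is made for them only; others in the source may bear on it.

Of the compounds shown here, three built on related cores have been tested in a functional assay for inhibition, with Homo sapiens as the target (a lower number here means a stronger inhibitor, a higher number a weaker inhibitor), and none of them has given a number. Compound 1 `CNc1nncc2c(C)ncn12` reports a limit of the assay, > 48000 nM, rather than a measured value. Compound 2 `CCCc1cnc(Nc2cc[nH]n2)n2c(CCC)nc(C)c12` likewise reports only a limit, > 48000 nM. Compound 3 `CCCc1nnc(S)n2c(CCC)nc(C)c12` also stops at a limit, > 48000 nM. Compound 2 therefore stands with the others: all three sit at the limit of > 48000 nM in this assay, at which 3 of the 3 values shown sit, and nothing separates them.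

Compound 4 `CCCc1nc(C)c2c(C)cnc(Nc3cc[nH]n3)n12` is the next compound to be measured. It keeps the whole of compound 2 except for one chain, where the change is hydrogen in place of ethyl on a saturated chain carbon bound to an aromatic carbon; read one bond further out, the same change is propyl to methyl. Going by the values given here, no measured pair shows what such a shortening does, so the only guide is that compound 2 gives > 48000 nM, a limit and not a number. Among the compounds with values here, with every value so far resting at that limit, the expected step of a number no higher from compound 2 to compound 4 (the limit leaves the size open) is none beyond the usual scatter. Compound 4 is therefore expected to give 48000 nM in this assay, within a range of 20000 nM to 200000 nM, and most likely to report only a limit again.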

Compound 4, half-maximal inhibitory concentration: > 48000 nM
Compound 4: no number, only a limit (the forecaster's own chance of this, stated with the estimate: 80%); the middle value lies on the limit itself.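

Compound 2 and compound 4 each report only a limit in this assay, so no step can be read from the change of ethyl to hydrogen. The compounds shown leave open what that change does to inhibition, and whether any of these compounds has a measurable value, because every result rests at the same point: the limit of > 48000 nM in this assay, at which 4 of the 4 values shown sit.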